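A few compounds are considered here, and "the series" means these few. Any claim that something is new, unique, unknown or untested is made for them only; others in the source may bear on it.

Compound 2 `CC1CCN(c2c(S(=O)(=O)c3ccc(F)c(F)c3)cnc3cc(Cl)ccc23)CC1` gives 90% in an assay on isolated protein for displacement of a labelled ligand from metabotropic glutamate receptor 5 (Homo sapiens), with a stated time of 60 min, tested at 1 uM; on this read-out lower numbers stand for less inhibition and higher numbers for more inhibition at the one concentration tested (going by the name of the read-out). Among the three measured compounds it stands second highest: compound 1 `CC1CCN(c2c(S(=O)(=O)c3ccc(F)cc3)cnc3ccc(F)cc23)CC1` gives 87% and compound 3 `CC1CCN(c2c(S(=O)(=O)c3ccc(F)c(F)c3)cnc3cc(F)ccc23)CC1` gives 94%, and both of these lie within the scatter of compound 2. Among the measured compounds shown here, the single one-change step that has been measured, a number 4 percentage points higher from compound 2 to compound 3 (within the scatter), swaps fluoro in place of chloro on an aromatic carbon and lies within the scatter. Compound 4 `Cc1ccc(S(=O)(=O)c2cnc3cc(Cl)ccc3c2N2CCC(C)CC2)cc1C` differs from compound 2 by 3,4-dimethylphenyl in place of 3,4-difluorophenyl on a sulfonyl sulfur. For the measured compounds named here, no measured step alters the group on the sulfonyl sulfur; the only recorded step changes a halogen elsewhere in the molecule, so there is no direct guide for the 3,4-dimethylphenyl group. Going by the values given here, since the three measured numbers sit close together and the one recorded step is small, compound 4 is expected to show a number 5 percentage points lower from compound 2 to compound 4 (within the scatter) in this assay, that is, no step beyond the scatter. The estimate for compound 4 is 85%, with a range from 70% to 95%.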

Compound 4, a percentage reported as inhibition, at one concentration (the size of the read-out at that concentration, not a potency): 86%
Beside the measured number, compound 4's estimate is 1 percentage points below it, within the range that was stated.
By their numbers in this assay, from the lowest: compounds 4, 1, 2 and 3 (each within the scatter of the next).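

In this assay, among the compounds shown here, the first measured change on the sulfonyl sulfur gives a number 4 percentage points lower from compound 2 to compound 4 (within the scatter). Replacing 3,4-difluorophenyl with 3,4-dimethylphenyl removes both fluorines and keeps the number of heavy atoms and the six-membered aromatic ring, so at the one concentration tested, this pair shows that the read-out does not depend on fluorine in this group. This holds only for this one exchange on the chloro-bearing core shared by compound 2 and compound 4, and no information available bears on why the two numbers stay so close.

Going by these compounds, what happens with a group on the sulfonyl sulfur that is not a substituted phenyl, such as a pyridine or a simple alkyl chain, remains open. A single-concentration reading also leaves open whether compound 2 and compound 4 would differ in potency.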